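Chloro in Place of Trifluoromethyl on Compound 1

The compounds below may be only part of what the source reports. "The series", "measured", "known", "first", "only" and "open" are said of these compounds alone.

In a physicochemical assay for lipophilicity, at pH 7.4 (on this read-out higher numbers stand for higher lipophilicity and lower numbers for lower lipophilicity), compound 1 (`CNC(=O)c1sc(N2CC3CC2(CNC(=O)c2c[nH]c4ncc(C(F)(F)F)cc24)C3)nc1C(F)(F)F`) gives 4.2 as its reading, the higher of the two numbers available. Going by the values given here, the only other measured compound, compound 2 (`C[C@@H]1CN(c2cnc(Nc3cc(F)c(OCC4CC4)c(F)c3)nc2NC2CCOCC2)CCN1`), gives 3.2 on the same scale, a gap beyond the usual scatter. Among the compounds with values here, that pair differs in more than one place, so it offers no measured step for a single change. Compound 3 (`CNC(=O)c1sc(N2CC3CC2(CNC(=O)c2c[nH]c4ncc(Cl)cc24)C3)nc1C(F)(F)F`) keeps the core of compound 1. The change (chloro in place of trifluoromethyl on an aromatic carbon) puts chloro in place of trifluoromethyl on an aromatic carbon of a six-membered aromatic ring with 1 nitrogen. Within the data shown here, no measured pair shows this change, so the expectation is a judgement only. In this assay a small fall is expected, with a number 0.30 log units lower from compound 1 to compound 3 (within the scatter) as the estimated step, which may not clear the usual scatter. The expected value for compound 3 is 3.9 with a range from 3.5 to 4.3 on repeated measurement.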

Compound 3, distribution coefficient: 4
Compound 3: the middle estimate sits 0.10 log units below what was measured; the range from low to high includes it.
By their numbers in this assay, from the lowest: compound 2; then compounds 3 and 1 (each within the scatter of the next).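

In this assay, chloro in place of trifluoromethyl on an aromatic carbon of the six-membered aromatic ring with 1 nitrogen gives a number 0.20 log units lower from compound 1 to compound 3 (within the scatter), the only measured step for a single change among the compounds shown. At this position, then, the read-out does not separate the two groups, even though chloro has fewer heavy atoms than trifluoromethyl. No available measurement bears on the reason for this result.

On these data alone, whether an amine, a nitrile or a carboxylic acid on the same aromatic carbon would also stay within the scatter of compound 1 remains open. So does whether chloro in place of the second trifluoromethyl of compound 1, which compound 3 keeps, would give a similar step.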